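From Compound 1 to Compound 4 in the Electroshock Model

The source may report more compounds than this note shows. Statements on the series, on what has been measured and on what is new or still open speak of the compounds shown alone.

Compound 1 `CC(C(=O)N1CCN(c2ccc(Cl)cc2)CC1)N1C(=O)CCC1=O` — 0%
Compound 2 `CC(C(=O)N1CCN(c2ccc(C(F)(F)F)cc2)CC1)N1C(=O)CCC1=O` — 0%
Compound 3 `CC(C(=O)N1CCN(c2ccccc2C(F)(F)F)CC1)N1C(=O)CCC1=O` — 75%

In a functional assay on the whole organism (strain Swiss) with Mus musculus as the target, in the maximal electroshock model, with a stated time of 1 h, at a dose of 300 mg/kg by the intraperitoneal route (on this read-out higher numbers stand for a stronger effect at the one dose given and lower numbers for a weaker effect), compound 1 gives 0%. It stands level with compound 2 at the digits shown, and together these two are the lowest of the three numbers; compound 3 lies far above both, well beyond the scatter. Compound 4 `CC(C(=O)N1CCN(c2cccc(F)c2)CC1)N1C(=O)CCC1=O` differs from compound 1 in one place: 3-fluorophenyl in place of 4-chlorophenyl on an amine nitrogen in a ring. Within the data shown here, the only measured step that touches this place is no change at the digits printed from compound 1 to compound 2 (within the scatter), where one group replaced another and the read-out stayed flat. Among the measured compounds shown here, compound 2 and compound 3 both bear a trifluoromethyl group, yet compound 2 gives 0% while compound 3 gives 75%, so where the group sits on the aromatic ring clearly matters, and no measured step covers the place a 3-fluorophenyl occupies. A rise beyond the scatter is therefore possible but far from assured, and the step of a number 25 percentage points higher from compound 1 to compound 4 (beyond the scatter) is expected to be modest and uncertain. For compound 4 the estimate is 25%, within 0% to 75%.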

Compound 4, a percentage reported as activity, at one dose (the size of the read-out at that dose, not a potency): 75%
Compound 4: the middle estimate sits 50 percentage points below what was measured; the measured number falls inside the stated range.
By their numbers in this assay, from the lowest: compounds 1 and 2 (each within the scatter of the next); then compounds 3 and 4 (each within the scatter of the next).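

In this assay, replacing 4-chlorophenyl with 3-fluorophenyl on the amine nitrogen in the ring gives a number 75 percentage points higher from compound 1 to compound 4 (beyond the scatter), so this position, flat in the earlier step from chloro to trifluoromethyl, can carry a large change. Compound 4 gives 75% and compound 3 gives 75%, so a substituted phenyl group other than a 4-substituted one can reach this level, and the two groups exchanged here have the same heavy-atom count and the same carbon-only aromatic ring. No measurement at hand explains the step.

The compounds shown leave open whether the step follows the change of halogen or the change in where it sits on the ring, as both change together here. On these data alone, how a methoxy group or an amine on that phenyl ring would read also remains open.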